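The source may hold more compounds than are shown below. What is called first, only, known or untested is meant among the compounds shown, and "the series" means these compounds.

In a functional assay on MDA-MB-468 cells (Homo sapiens) for antiproliferative activity, read by sulforhodamine B assay, with a stated time of 72 h (on this read-out lower numbers stand for stronger inhibition and higher numbers for weaker inhibition), compound 1, with the structure `Fc1ccc(/C=C/c2cc3ccccc3nc2Cl)cc1`, gives 120 nM. Compound 2, with the structure `COc1ccc2nc(Cl)c(/C=C/c3ccc(F)cc3)cc2c1`, differs from it by a single change: methoxy in place of hydrogen on an aromatic carbon. In this assay compound 2 gives 14800 nM. That change produced a 120-fold higher number from compound 1 to compound 2 (2.09 log units; beyond the scatter), a weakening of the inhibition on this scale. Compound 3, with the structure `FC(F)(F)c1cccc(/C=C\c2cc3ccccc3nc2Cl)c1`, carries a different core; how that core differs from the core of compound 1 is not broken down here. In this assay compound 3 gives 3700 nM.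

Compound 4, with the structure `COc1ccc2nc(Cl)c(/C=C\c3cccc(C(F)(F)F)c3)cc2c1`, has not yet been measured. It stands to compound 3 as compound 2 stands to compound 1, through the same change, made at the same place: methoxy in place of hydrogen on an aromatic carbon. Going by the values given here, whether this core answers the change as the first one did is unknown, since only one example of the step is available. Compound 4 is expected to give a clearly higher number, estimated at 60000 nM, because the same change produced a 120-fold higher number from compound 1 to compound 2 (2.09 log units; beyond the scatter). That estimate means a 16-fold higher number from compound 3 to compound 4 (1.21 log units; beyond the scatter), a step of the same kind, taken as somewhat smaller to allow for the change of core.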

Compound 4, half-maximal inhibitory concentration: 3910 nM
For compound 4 the middle estimate is 15-fold (1.19 log units) above the measured one; the whole stated range lies above it.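

In this assay, putting methoxy in place of hydrogen on an aromatic carbon gives a 1.1-fold higher number from compound 3 to compound 4 (0.02 log units; within the scatter), so on this core the two numbers cannot be told apart. Set beside the earlier example, the same change clearly does not carry the same size of effect from one core to the other: the same change on two cores in this assay, a 120-fold higher number (2.09 log units; beyond the scatter) from compound 1 to compound 2 and a 1.1-fold higher number (0.02 log units; within the scatter) from compound 3 to compound 4, 120-fold (2.07 log units) apart, beyond the scatter of two such steps. This means the large weakening seen on the core of compound 1 cannot be treated as a rule for the series, but two pairs alone do not show which feature of the cores sets them apart, or why.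

The compounds shown leave open how other groups at this same place, such as a hydroxyl, an amine or a longer ethoxy chain, would behave on either core. They also leave open whether a further core would answer methoxy as the core of compound 1 does or as the core of compound 3 does.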